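Replacing tert-butyl with 2-hydroxyphenyl on the carbonyl carbon

The source may hold more compounds than are shown below. What is called first, only, known or untested is meant among the compounds shown, and "the series" means these compounds.

Of the compounds shown here, three sharing one core have been measured in a functional assay on the whole organism (strain CF-1) with Mus musculus as the target, in the writhing test, with a stated time of 15 min; a higher number here means that more compound is needed for the effect, a lower number that less compound is needed. Compound 1 `O=C(/N=C1\NC2(CCCCO2)CCS1)Nc1ccccc1` carries an anilino group on the carbonyl carbon; in this assay compound 1 reaches only a limit, > 200 mg/kg. Compound 2 `Cc1ccc(C(=O)/N=C2\NC3(CCCCO3)CCS2)cc1` carries a 4-methylphenyl group in that place, and in this assay compound 2 gives 60 mg/kg. Compound 3 `CC(C)(C)C(=O)/N=C1\NC2(CCCCO2)CCS1`, with a tert-butyl group there, gives 200 mg/kg in this assay; of the two plain numbers compound 3 stands highest, and its nearest neighbour is compound 2, as the step of a 3.3-fold higher number from compound 2 to compound 3 (0.52 log units; beyond the scatter) shows. The step of an at least 3.3-fold lower number from compound 1 to compound 2 (0.52 log units; beyond the scatter) favours the aryl group over the anilino, while a number no higher from compound 1 to compound 3 (the limit leaves the size open) leaves its size open because compound 1 sits at the limit of > 200 mg/kg in this assay, at which 1 of the 3 values shown sits.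

Compound 4 `O=C(/N=C1\NC2(CCCCO2)CCS1)c1ccccc1O` differs from compound 3 by 2-hydroxyphenyl in place of tert-butyl on a carbonyl carbon. Going by the values given here, of the measured steps, the one exchanging an aryl group for tert-butyl in the same place, a 3.3-fold higher number from compound 2 to compound 3 (0.52 log units; beyond the scatter), bears on it most; read in reverse it points to a lower number for compound 4. Among the compounds with values here, no measured pair shows what the hydroxyl on the ring adds, so the estimate stays close to compound 2. For compound 4 the expected step in this assay is a 2.9-fold lower number from compound 3 to compound 4 (0.46 log units; beyond the scatter). Compound 4 is therefore expected to give about 70 mg/kg in this assay, within a range from 30 mg/kg to 200 mg/kg.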

Compound 4, dose for half-maximal effect: > 200 mg/kg
Compound 4: no number, only a limit (the forecaster's own chance of this, stated with the estimate: 15%); middle value at least 2.8-fold (0.45 log units) from the limit.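

In this assay compound 4 reaches only a limit, > 200 mg/kg. An aromatic ring on the carbonyl carbon is therefore not enough on its own to give the lower number: with 2-hydroxyphenyl in place of 4-methylphenyl the result is an at least 3.3-fold higher number from compound 2 to compound 4 (0.52 log units; beyond the scatter), so the advantage of the 4-methylphenyl group does not extend to this aryl group, and what the ring carries matters at this position. With 2-hydroxyphenyl in place of tert-butyl the result is a number no lower from compound 3 to compound 4 (the limit leaves the size open), and neither the size of that step nor the comparison with the anilino group can be read, because these comparisons rest on a limit: the limit of > 200 mg/kg in this assay, at which 2 of the 4 values shown sit.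

The compounds shown leave open whether the difference from 4-methylphenyl comes from gaining the hydroxyl, from losing the methyl, or from where the group sits on the ring; a plain phenyl, 4-hydroxyphenyl or 2-methylphenyl group on the carbonyl carbon would separate these readings. As far as these compounds go, how far the number of compound 4 lies beyond its limit also remains open.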